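A few compounds are considered here, and "the series" means these few. Any claim that something is new, unique, unknown or untested is made for them only; others in the source may bear on it.

Measured so far in a functional assay on MCF7 cells (Homo sapiens) for cytotoxicity, read by CellTiter-Glo, with a stated time of 5 days; on this read-out lower numbers stand for stronger inhibition and higher numbers for weaker inhibition:
Compound 1, `O=C(O)/C=C/c1ccc(/C(=C(\c2ccc(F)cc2Cl)C2CCC2)c2ccc3[nH]nc(F)c3c2)cc1`, gives 2 nM
Compound 2, `O=C(O)/C=C/c1ccc(/C(=C(\c2ccc(C(F)(F)F)cc2Cl)C2CCC2)c2ccc3[nH]nc(F)c3c2)cc1`, gives 8.2 nM
Compound 3, `O=C(O)/C=C/c1ccc(/C(=C(\c2ncc(F)cc2Cl)C2CCC2)c2ccc3[nH]nc(F)c3c2)cc1`, gives 1.7 nM

Compound 3 has the lowest number of the three in this assay, but it sits within the usual scatter of compound 1, as the step of a 1.2-fold lower number from compound 1 to compound 3 (0.07 log units; within the scatter) shows, so the two cannot be ranked against each other. Only compound 2 is clearly set apart: a 4.8-fold lower number from compound 2 to compound 3 (0.68 log units; beyond the scatter) is a modest step beyond the scatter.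

Compound 4, `N#Cc1cc(Cl)cnc1/C(=C(\c1ccc(/C=C/C(=O)O)cc1)c1ccc2[nH]nc(F)c2c1)C1CCC1`, has not yet been measured. It differs from compound 3 in one place: 5-chloro-3-cyanopyridin-2-yl in place of 3-chloro-5-fluoropyridin-2-yl on a double-bonded chain carbon bound to a double-bonded chain carbon and a saturated ring carbon. For the measured compounds named here, no measured pair swaps a fluoro for a nitrile on this ring, so the closest guide is a 4.1-fold higher number from compound 1 to compound 2 (0.61 log units; beyond the scatter), where a fluoro on the same aromatic ring gave way to a trifluoromethyl and the number rose modestly. The pyridine ring itself, judged from a 1.2-fold lower number from compound 1 to compound 3 (0.07 log units; within the scatter), made no difference beyond the scatter.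

On that basis a small rise in the number is expected for compound 4, and the expected step of a 2.1-fold higher number from compound 3 to compound 4 (0.31 log units; beyond the scatter) is at the edge of the scatter. Compound 4 is therefore estimated at 3.5 nM in this assay, with a likely range from 1.5 nM to 10 nM.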

Compound 4, half-maximal inhibitory concentration: 1.1 nM
The estimate for compound 4 lay 3.2-fold (0.50 log units) above the measured number, and the stated range ends above it.
By their numbers in this assay, from the lowest: compounds 4, 3 and 1 (each within the scatter of the next); then compound 2.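

In this assay, for the compounds shown here, the step of a 1.5-fold lower number from compound 3 to compound 4 (0.19 log units; within the scatter) and the step of a 1.8-fold lower number from compound 1 to compound 4 (0.26 log units; within the scatter) both lie within the scatter, so this place, on a double-bonded chain carbon, accepts a pyridine bearing a nitrile, a group absent from the earlier compounds, with no change that can be told apart from repeat-measurement noise. Going by these compounds alone, the step of a 7.5-fold lower number from compound 2 to compound 4 (0.87 log units; beyond the scatter) lies beyond the scatter, which leaves 2-chloro-4-(trifluoromethyl)phenyl as the only group at this place whose compound stands apart from the other three. No measurement offered here explains these results.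

Compound 3 and compound 4 differ in more than one feature of the pyridine, since the fluoro is lost and the nitrile is gained while the chloro stays on the ring under a different numbering, so the compounds shown cannot say which feature, if any, matters on its own. They also leave open how a pyridine bearing an amine or a methoxy group at this place would behave, and whether a number clearly lower than those of compound 1, compound 3 and compound 4 can be reached here at all.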